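A few compounds are considered here, and "the series" means these few. Any claim that something is new, unique, unknown or untested is made for them only; others in the source may bear on it.

Measured in a functional assay on KB cells (Homo sapiens) for antiproliferative activity, read by sulforhodamine B assay, with a stated time of 3 days; a higher number here means a weaker inhibitor of growth, a lower number a stronger inhibitor of growth:
- compound 1 `O=C(Nc1ccc(C(F)(F)F)cc1)c1cccc(Nc2ncc(F)c(Nc3ccc(F)cc3)n2)c1`: > 10000 nM (a limit of the assay, not a number)
- compound 2 `O=C(Nc1cccc(Nc2ncc(F)c(Nc3ccc(F)cc3)n2)c1)c1cnccn1`: 23600 nM
- compound 3 `COCC(=O)Nc1cccc(Nc2ncc(F)c(Nc3ccc(F)cc3)n2)c1`: 6250 nM

Compound 3 has the lower of the two actual numbers, and compound 2 is its nearest neighbour: a 3.8-fold lower number from compound 2 to compound 3 (0.58 log units; beyond the scatter). The result for compound 1 is a limit and gives no rank.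

Compound 4 `O=C(NCCO)c1cccc(Nc2ncc(F)c(Nc3ccc(F)cc3)n2)c1` has the same atoms as compound 3, joined differently, with (2-hydroxyethyl)carbamoyl in place of ((methoxymethyl)carbonyl)amino on an aromatic carbon. Among the measured compounds shown here, no measured step covers this exchange. For the measured compounds named here, the only size guide is the modest 3.8-fold lower number from compound 2 to compound 3 (0.58 log units; beyond the scatter), so a small step towards a higher number is expected in this assay, no larger than that one. The direction rests on a single compound. Compound 1, which also carries a carbamoyl on this ring, gives a limit, > 10000 nM. Compound 4 could likewise be reported only as a limit. The expected step is a 1.5-fold higher number from compound 3 to compound 4 (0.18 log units; within the scatter). For compound 4 the estimated value is 9500 nM, with an expected range of 3000 nM to 30000 nM.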

Compound 4, concentration for 50% growth inhibition: 12400 nM
For compound 4 the middle estimate is 1.3-fold (0.12 log units) below the measured one; the range from low to high includes it.
By their numbers in this assay, from the lowest: compounds 3, 4 and 2 (each within the scatter of the next, the first and the last beyond it).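

In this assay, joining the same atoms the other way round, as (2-hydroxyethyl)carbamoyl in place of ((methoxymethyl)carbonyl)amino, gives a 2.0-fold higher number from compound 3 to compound 4 (0.30 log units; within the scatter), so at this place on the ring the change of attachment does not move the number beyond the scatter. The exchange of the pyrazin-2-yl amide for this carbamoyl, a 1.9-fold lower number from compound 2 to compound 4 (0.28 log units; within the scatter), also stays within the scatter, which places compound 4 within reach of both compound 2 and compound 3, although those two lie beyond the scatter of each other. The result for compound 1 is a limit of the assay, so its step to compound 4 cannot be read: the limit of > 10000 nM in this assay, at which 1 of the 4 values shown sits.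

On these data alone, whether an amine or a carboxylic acid at the end of the 2-hydroxyethyl chain, or a longer chain, would move the number beyond the scatter remains open. Also open, as far as these compounds go, is how the carbamoyl would read at another place on this ring.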